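A few compounds are considered here, and "the series" means these few. Any claim that something is new, unique, unknown or untested is made for them only; others in the source may bear on it.

Of the compounds shown here, three built on one shared core have been tested. Compound 1 `Cc1sc(N)c(C(=O)c2ccc(Cl)cc2)c1-c1ccccc1`, compound 2 `CC(C)(C)Cc1csc(N)c1C(=O)c1cccc(Cl)c1` and compound 3 `CC(C)(C)Cc1c(-c2cccnc2)sc(N)c1C(=O)c1ccc(Cl)cc1` were each run in an assay on CHO cells for displacement of a labelled ligand from adenosine receptor A1 (Homo sapiens), read by scintillation counting, tested at 10 uM; on this read-out lower numbers stand for less inhibition and higher numbers for more inhibition at the one concentration tested (going by the name of the read-out). Compound 1 gives 1%, compound 2 gives 2%, and compound 3 gives 1%. Compound 3 thus stands level with compound 1 at the digits shown, and its gap to compound 2 lies within the usual scatter, so all three show essentially no inhibition at the single concentration tested. Compound 4 `CC(C)(C)Cc1c(-c2ccc(Cl)cc2)sc(N)c1C(=O)c1ccc(Cl)cc1` has not yet been measured; it differs from compound 3 by 4-chlorophenyl in place of pyridin-3-yl on an aromatic carbon. For the measured compounds named here, no step between measured compounds is available, and with compound 3 at 1%, the step of a number 1 percentage points higher from compound 3 to compound 4 (within the scatter) is expected to be none beyond the scatter. Compound 4 is therefore expected to give 2%, with a range from 0% to 12%.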

Compound 4, a percentage reported as inhibition, at one concentration (the size of the read-out at that concentration, not a potency): 1%
The estimate for compound 4 lay 1 percentage points above the measured number; low and high end bracket the measured number.
By their numbers in this assay, from the lowest: compounds 1, 3, 4 and 2 (each within the scatter of the next).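

Putting 4-chlorophenyl in place of pyridin-3-yl on the aromatic carbon next to the ring sulfur brings no change at the digits printed from compound 3 to compound 4 (within the scatter) in this assay. At this position, then, exchanging a ring that holds a nitrogen for an all-carbon ring bearing chlorine leaves both compounds with essentially no inhibition. Nothing measured here explains this result. As far as these compounds go, it remains open whether a different kind of group at this position, such as an amine, a carboxylic acid or a longer alkyl chain, would give clear inhibition. From the compounds shown here alone, whether changing the neopentyl group would do so also remains open.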